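Pentyl in Place of Bromo on the Aryl Triazole Arm

The source may hold more compounds than are shown below. What is called first, only, known or untested is meant among the compounds shown, and "the series" means these compounds.

Measured compounds:
compound 1, `O=C1O[C@H]([C@@H](O)Cn2cc(-c3ccc(Br)cc3)nn2)C(OCc2ccccc2)=C1OCc1ccccc1`: 5830 nM
compound 2, `O=C1O/C(=C\Cn2cc(-c3cc(F)cc(F)c3)nn2)C(OCc2ccccc2)=C1OCc1ccccc1`: "not active" (no number reported)

The series was tested in a functional assay on CFPAC-1 cells (Homo sapiens) for antiproliferative activity, read by MTT assay, with a stated time of 72 h; on this read-out higher numbers stand for weaker inhibition and lower numbers for stronger inhibition. For the measured compounds named here, compound 1 gives 5830 nM, and this is the only number in the set: compound 2 was reported without a number, so compound 1 stands alone as the single measured anchor, neither strongest nor weakest by comparison. Nothing else carries a value. Going by the values given here, no pair of measured compounds differs in a single place, so no measured step is available to calibrate the next change.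

Compound 3, `CCCCCc1ccc(-c2cn(C[C@H](O)[C@H]3OC(=O)C(OCc4ccccc4)=C3OCc3ccccc3)nn2)cc1`, is the next compound to be measured in this assay. It differs from compound 1 by pentyl in place of bromo on an aromatic carbon.

Among the compounds with values here, with no measured step to lean on, the size of the change is uncertain. Compound 3 is expected to give 3500 nM, with a range from 1000 nM to 12000 nM. The corresponding step of a 1.7-fold lower number from compound 1 to compound 3 (0.22 log units; within the scatter) is expected to be modest, leaning toward stronger inhibition, but it could well fall within the usual scatter of repeated measurements.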

Compound 3, half-maximal inhibitory concentration: 9890 nM
Compound 3: the middle estimate sits 2.8-fold (0.45 log units) below what was measured; low and high end bracket the measured number.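

In this assay, for the compounds shown here, pentyl in place of bromo on an aromatic carbon, para to a large group, gives a 1.7-fold higher number from compound 1 to compound 3 (0.23 log units; within the scatter), the first measured step at this position in the set. The change from 4-bromophenyl to 4-pentylphenyl replaces a single bromine atom with a chain of five carbons, yet the two compounds cannot be told apart on this read-out, so at this position a chain of this length and a bromo group read alike in these cells. No measurement shown here bears on why the two groups read alike.

The compounds shown leave open whether this position would stay as insensitive to a primary amine, a carboxylic acid or a longer chain such as decyl, since a single step within the scatter defines no trend across substituents. Compound 2 differs from compound 1 in more than one place, so its report as not active, without a number, cannot be tied to any single feature of its structure.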